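Growth inhibition notes: the step from compound 3 to compound 4

A few compounds are considered here, and "the series" means these few. Any claim that something is new, unique, unknown or untested is made for them only; others in the source may bear on it.

Measured so far in a functional assay on NUGC-3 cells (Homo sapiens) for inhibition, read by sulforhodamine B assay; a higher number here means a weaker inhibitor of growth, a lower number a stronger inhibitor of growth:
compound 1 `Cc1ccccc1CN1CC=C(CCC(=O)NO)C1=O` gives 4280 nM
compound 2 `CCOc1ccc(CCCN2CC=C(CCC(=O)NO)C2=O)cc1` gives 2200 nM
compound 3 `Cc1ccc(CN2CC=C(CCC(=O)NO)C2=O)cc1` gives 4280 nM

All three numbers lie within the usual scatter of one another. Compound 3 is level with compound 1 at the digits shown, and the gap between compound 3 and compound 2 is also within the scatter, so the three measured compounds cannot be ranked on these data.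

Compound 4 `CC(C)(C)c1ccc(CN2CC=C(CCC(=O)NO)C2=O)cc1` is not yet measured in this assay. It differs from compound 3 in one place: tert-butyl in place of methyl on an aromatic carbon. Among the compounds with values here, no pair of measured compounds shows this change, so its effect has to be taken as unknown. Since the three measured compounds, with their different groups on the ring, all stay within the scatter, a step of no more than the scatter is expected here as well, with no preferred direction. The expected step of a 1.2-fold lower number from compound 3 to compound 4 (0.09 log units; within the scatter) is therefore small. Compound 4 is expected to give 3500 nM in this assay, with a range from 1300 nM to 9000 nM.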

Compound 4, concentration for 50% growth inhibition: 720 nM
For compound 4 the middle estimate is 4.9-fold (0.69 log units) above the measured one; measured number outside the range, below it.
By their numbers in this assay, from the lowest: compound 4; then compounds 2, 1 and 3 (each within the scatter of the next).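

Within the data shown here, the aromatic carbon para to a large group is sensitive to its substituent in this assay: tert-butyl in place of methyl gives a 5.9-fold lower number from compound 3 to compound 4 (0.77 log units; beyond the scatter), the first step in this set that lies beyond the scatter. The change adds only carbon, with no ring, no hydrogen-bond donor or acceptor and no net charge on either side, so a step of this size does not require any of these features in the entering group. Nothing available bears on what lies behind the step.

Open, from the compounds shown here alone, is whether isopropyl or ethyl at this carbon would give a number between those of compound 3 and compound 4, and how a carboxylic acid or an amine there would read. Also open, going by these compounds, is whether tert-butyl has the same effect with a longer chain between the aromatic ring and the shared core.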